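This account rests on a few compounds, and the source may have more. Where it says the series, first, only, none or still open, it means among the compounds named here.

Working notes on the series. Compound 1 `NS(=O)(=O)c1nnc(NCc2nc3cc([N+](=O)[O-])ccc3[nH]2)s1` and compound 2 `O=[N+]([O-])c1ccc2[nH]c(CNc3c([N+](=O)[O-])ccc4ncccc34)nc2c1` share a nitro-bearing benzimidazole portion but differ in the rest of the molecule; how the two cores differ is not broken down here. In a functional assay on HepG2 cells (Homo sapiens) for cytotoxicity, read by MTT assay (a higher number here means a weaker inhibitor, a lower number a stronger inhibitor), compound 1 gives 184000 nM, and compound 2 gives 265000 nM. Compound 3 `O=[N+]([O-])c1ccc2ncccc2c1NCc1nc2ccccc2[nH]1` gives 259000 nM. Compound 3 arises from compound 2 by hydrogen in place of nitro on an aromatic carbon, and that step came to a 1.0-fold lower number from compound 2 to compound 3 (0.01 log units; within the scatter). Compound 4 `NS(=O)(=O)c1nnc(NCc2nc3ccccc3[nH]2)s1`, not yet measured, arises from compound 1 by the same change, (hydrogen in place of nitro on an aromatic carbon), on the same place of the same kind of ring. Because the measured step of a 1.0-fold lower number from compound 2 to compound 3 (0.01 log units; within the scatter) was flat, the step of a 1.0-fold higher number from compound 1 to compound 4 (0.01 log units; within the scatter) is expected to be flat as well. Compound 4 is therefore estimated to give 190000 nM, roughly between 100000 nM and 360000 nM.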

Compound 4, half-maximal inhibitory concentration: 162000 nM
The estimate for compound 4 lay 1.2-fold (0.07 log units) above the measured number; low and high end bracket the measured number.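

In this assay, hydrogen in place of nitro on the core of compound 1 gives a 1.1-fold lower number from compound 1 to compound 4 (0.06 log units; within the scatter) and so stays within the scatter. The step on this core and the earlier step do not differ, so on these two cores the change carries over as a flat step: the same change on two cores in this assay, a 1.0-fold lower number (0.01 log units; within the scatter) from compound 2 to compound 3 and a 1.1-fold lower number (0.06 log units; within the scatter) from compound 1 to compound 4, 1.1-fold (0.05 log units) apart, within the scatter of two such steps. For the compounds shown here, this rests on only two pairs, both with high numbers, and it does not show that the change would stay flat on a third core or in any other read-out.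

The compounds shown leave open what other groups at this place, such as an amine or a carboxylic acid, would do. They also leave open whether a flat step would hold with a longer chain joining the two ring portions.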